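A few compounds are considered here, and "the series" means these few. Any claim that something is new, unique, unknown or untested is made for them only; others in the source may bear on it.

In a physicochemical assay for solubility, in phosphate buffer, measured as thermodynamic solubility, at pH 7.4 (on this read-out lower numbers stand for lower solubility and higher numbers for higher solubility), compound 3 `CS(=O)(=O)NCCCc1cn(-c2ccc(Br)cc2)nc1-c1ccc(Cl)cc1` gives < 5000 nM as a limit of the assay and not a number. Compound 2 `CN(C(=O)CCc1cn(-c2ccc(Br)cc2)nc1-c1ccc(Cl)cc1)S(C)(=O)=O` gives < 5000 nM as a limit too. This is the limit of < 5000 nM in this assay, at which 2 of the 3 values shown sit, and it leaves compound 3 without a readable place on the scale. Only compound 1 `CS(=O)(=O)NC(=O)CCc1cn(-c2ccc(Br)cc2)nc1-c1ccc(Cl)cc1` gives a number (170000 nM) and it carries the (methylsulfonyl)carbamoyl group. Methyl in place of hydrogen on its amide-type nitrogen gives an at least 34-fold lower number from compound 1 to compound 2 (1.53 log units; beyond the scatter) and the change to (methanesulfonamido)methyl gives an at least 34-fold lower number from compound 1 to compound 3 (1.53 log units; beyond the scatter) while a step that the two limits leave unreadable from compound 2 to compound 3 adds nothing.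

The step in question leads to compound 4 `CC(=O)NS(=O)(=O)CCc1cn(-c2ccc(Br)cc2)nc1-c1ccc(Cl)cc1` with acetylsulfamoyl in place of (methanesulfonamido)methyl on a saturated chain carbon, two bonds along the chain from an aromatic carbon as the counted difference: acetylsulfamoyl in place of (methanesulfonamido)methyl on a saturated chain carbon, two bonds along the chain from an aromatic carbon. Compound 4 has no methyl on that nitrogen and carries both carbonyl and sulfonyl in its chain, in swapped order, so it resembles compound 1 (170000 nM) more closely than compound 2 or compound 3. The two large measured steps therefore suggest a large expected rise, read here as an at least 12-fold higher number from compound 3 to compound 4 (1.07 log units; beyond the scatter) and uncertain in size given the swapped order. In this assay the estimate for compound 4 is 60000 nM and its range runs from 10000 nM to 250000 nM as an expected spread.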

Compound 4, solubility: 165000 nM
Compound 4: middle estimate off by 2.8-fold (0.44 log units), on the low side, and the stated range covers the measured number.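

In this assay, reversing the order of carbonyl and sulfonyl in the chain leaves no readable difference: a 1.0-fold lower number from compound 1 to compound 4 (0.01 log units; within the scatter). Acetylsulfamoyl in place of (methanesulfonamido)methyl gives an at least 33-fold higher number from compound 3 to compound 4 (1.51 log units; beyond the scatter), and acetylsulfamoyl in place of methyl(methylsulfonyl)carbamoyl gives an at least 33-fold higher number from compound 2 to compound 4 (1.51 log units; beyond the scatter). Among the four compounds, the measured high numbers therefore go with a chain nitrogen that carries a hydrogen, a carbonyl and a sulfonyl, at this place on a saturated chain carbon, two bonds along the chain from an aromatic carbon, and not with one order of those groups; compound 2 has the methyl on that nitrogen, compound 3 has no carbonyl, and neither goes against this pattern.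

On these data alone, the step between compound 2 and compound 3 cannot be read, so the separate contributions of the nitrogen methyl and the missing carbonyl remain unordered: the limit of < 5000 nM in this assay, at which 2 of the 4 values shown sit. Whether a carboxylic acid or a longer chain ending in acetylsulfamoyl would stay in the range of compound 1 and compound 4 remains open.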